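Chlorophenyl for pyridinyl in a trisubstituted pyridine series

This account rests on a few compounds, and the source may have more. Where it says the series, first, only, none or still open, it means among the compounds named here.

Measured so far in a functional assay on HCT-15 cells (Homo sapiens) for cytotoxicity, in the presence of a further agent that is not named here; a higher number here means a weaker inhibitor, a lower number a stronger inhibitor:
- compound 1, `Clc1cccc(-c2cc(-c3ccc(Cl)o3)cc(-c3cccs3)n2)c1`, gives 15500 nM
- compound 2, `Clc1ccc(-c2cc(-c3cccs3)nc(-c3ccccc3Cl)c2)o1`, gives 6190 nM
- compound 3, `Clc1ccc(-c2cc(-c3cccnc3)nc(-c3cccs3)c2)o1`, gives 1240 nM

Compound 3 stands lowest of the three numbers; the nearest is compound 2, a 5.0-fold lower number from compound 2 to compound 3 (0.70 log units; beyond the scatter), and the furthest is compound 1, a 13-fold lower number from compound 1 to compound 3 (1.10 log units; beyond the scatter). Both steps lie beyond the scatter, so compound 3 is the strongest inhibitor of the set.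

Compound 4, `Clc1ccc(-c2cc(-c3ccc(Cl)o3)cc(-c3cccs3)n2)cc1`, is not yet measured. It differs from compound 3 in one place: 4-chlorophenyl in place of pyridin-3-yl on an aromatic carbon. The two steps that bear on this change run the other way, a chlorophenyl group entering where pyridin-3-yl stood: a 13-fold lower number from compound 1 to compound 3 (1.10 log units; beyond the scatter) and a 5.0-fold lower number from compound 2 to compound 3 (0.70 log units; beyond the scatter). Read in reverse, both say that exchanging pyridin-3-yl for a chlorophenyl group gives a higher number in this assay, modest to large. The chlorine in compound 4 sits at a position not covered by compound 1 or compound 2, so the size is uncertain, but the direction is consistent. For compound 4 the expected step is therefore a 6.5-fold higher number from compound 3 to compound 4 (0.81 log units; beyond the scatter), towards a weaker inhibitor. Compound 4 is estimated at 8000 nM, with a range from 3000 nM to 22000 nM.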

Compound 4, half-maximal inhibitory concentration: 14200 nM
For compound 4 the middle estimate is 1.8-fold (0.25 log units) below the measured one; the range from low to high includes it.
By their numbers in this assay, from the lowest: compound 3; then compound 2; then compounds 4 and 1 (each within the scatter of the next).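

In this assay, 4-chlorophenyl completes the set of three chlorophenyl isomers at this place, and the exchange for pyridin-3-yl again costs activity (an 11-fold higher number from compound 3 to compound 4 (1.06 log units; beyond the scatter)), so all three isomers lie on the weaker side of compound 3. The chlorine position matters only in part: 4-chlorophenyl and 3-chlorophenyl do not separate (a 1.1-fold lower number from compound 1 to compound 4 (0.04 log units; within the scatter)), whereas 2-chlorophenyl stays apart from 4-chlorophenyl (a 2.3-fold higher number from compound 2 to compound 4 (0.36 log units; beyond the scatter)). Nothing available accounts for these differences.

The compounds shown leave open whether the advantage of pyridin-3-yl comes from its ring nitrogen or from the absence of chlorine, and an unsubstituted phenyl group at this place would separate the two. Pyridin-4-yl, or a phenyl ring carrying an amine, would test how far that advantage extends.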